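The source may hold more compounds than are shown below. What is called first, only, known or untested is meant among the compounds shown, and "the series" means these compounds.

Three compounds were measured in an assay for displacement of a labelled ligand from DNA repair protein REV1 (Homo sapiens), read by fluorescence polarization, with a stated time of 1 h, tested at 1 uM; on this read-out higher numbers stand for more inhibition at the one concentration tested (going by the name of the read-out) and lower numbers for less inhibition. Compound 1 `CCc1ccc(NC(=O)CN2CCN(c3ccc(F)cc3)CC2)cc1` gives 50% in this assay. Compound 2 `CCCC1CCc2c(sc(NC(=O)C3CCN(C(C)=O)CC3)c2C(N)=O)C1` gives 50% in this assay. Compound 3 `COC(=O)c1cc(C)sc1NC(=O)C1CCN(C(C)=O)CC1` gives 50% in this assay, level with compound 1 and compound 2 at the digits reported, and both of those values lie within the scatter of repeated measurements of compound 3. No pair among these three differs in only one place, so no single step can be read from them.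

Compound 4 `CCc1cc(C(=O)OC)c(NC(=O)C2CCN(C(C)=O)CC2)s1` has not yet been measured in this assay. It differs from compound 3 in one way: methyl in place of hydrogen on a saturated chain carbon bound to an aromatic carbon. Going by the values given here, nothing among the measured compounds bears on this kind of change, and the three values seen so far sit together without spread. The step from compound 3 to compound 4 is therefore expected to be none beyond the scatter, at no change at the digits printed from compound 3 to compound 4 (within the scatter). Compound 4 is expected to give 50% in this assay, with a range from 35% to 65%.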

Compound 4, a percentage reported as inhibition, at one concentration (the size of the read-out at that concentration, not a potency): 50%
Compound 4: the middle estimate sits on the measured number at the digits printed; measured number inside the range.
By their numbers in this assay, from the lowest: compounds 1, 2, 3 and 4 (each within the scatter of the next).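

In this assay, methyl in place of hydrogen on a saturated chain carbon bound to an aromatic carbon gives no change at the digits printed from compound 3 to compound 4 (within the scatter). Going by these compounds alone, the earlier compounds held no pair differing in one place, so this is the first reading at this position, and it shows that the change from methyl to ethyl there leaves the result within the scatter at the one concentration tested. No measurement shown here offers an explanation for this result.

The compounds shown leave open whether a longer chain such as propyl, an amine or a carboxylic acid on this same carbon would also stay within the scatter, and a single step establishes no trend at this position. Any difference in potency between the two compounds also remains unknown, since the read-out comes from one concentration only.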